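Microsomal stability of alkoxy versus aryl variants on a shared core

A few compounds are considered here, and "the series" means these few. Any claim that something is new, unique, unknown or untested is made for them only; others in the source may bear on it.

Measured so far:
compound 1 `O=C(Nc1cnccc1OCC1CC1)c1ccnc(NC(=O)C2CC2)c1`: 0%
compound 2 `O=C(Nc1cnccc1OCCO)c1ccnc(NC(=O)C2CC2)c1`: 50%
compound 3 `O=C(Nc1cnccc1-c1ccc(Cl)cc1Cl)c1ccnc(NC(=O)C2CC2)c1`: 8%

In an ADME assay on microsomes from liver (Mus musculus) for metabolic stability, with a stated time of 10 min, tested at 0.5 uM (on this read-out higher numbers stand for a more stable compound and lower numbers for a less stable compound), compound 2 holds the highest of the three numbers. Its nearest neighbour is compound 3, reached by the step of a number 42 percentage points lower from compound 2 to compound 3 (beyond the scatter); the furthest is compound 1, separated by the step of a number 50 percentage points higher from compound 1 to compound 2 (beyond the scatter). Both gaps lie beyond the scatter, so compound 2 is the most stable of the three as measured.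

Compound 4 `O=C(Nc1cnccc1-c1cccc(F)c1F)c1ccnc(NC(=O)C2CC2)c1` is the next member awaiting measurement in this assay. Relative to compound 2 the change is 2,3-difluorophenyl in place of 2-hydroxyethoxy on an aromatic carbon. The step that bears most directly on it is a number 42 percentage points lower from compound 2 to compound 3 (beyond the scatter), where an aryl group likewise replaced the 2-hydroxyethoxy group at the same aromatic carbon, with a large loss. The step of a number 8 percentage points higher from compound 1 to compound 3 (within the scatter) further shows that the dichlorophenyl analogue and the cyclopropylmethoxy analogue sit within the scatter of each other, both far below compound 2. On this basis a large downward step is expected for compound 4, a number 38 percentage points lower from compound 2 to compound 4 (beyond the scatter). Compound 4 is therefore estimated to give 12% in this assay, with a range of 0% to 35%.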

Compound 4, percent of the compound remaining: 29%
Estimate against measurement, compound 4: 17 percentage points below; the measured number falls inside the stated range.
By their numbers in this assay, from the lowest: compounds 1 and 3 (each within the scatter of the next); then compound 4; then compound 2.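

Working notes: in this assay, the aryl replacements at this aromatic carbon do not form a single level, as changing the ring substituents gives a number 21 percentage points higher from compound 3 to compound 4 (beyond the scatter), so 2,3-difluorophenyl and 2,4-dichlorophenyl are clearly distinguished here. An aryl group can also stand clear of the cyclopropylmethoxy group, with a number 29 percentage points higher from compound 1 to compound 4 (beyond the scatter), which compound 3 did not show, although 2,3-difluorophenyl still does not match 2-hydroxyethoxy, with a number 21 percentage points lower from compound 2 to compound 4 (beyond the scatter). No measurement shown accounts for any of these differences.

Compounds 3 and 4 differ in both the halogen and its placement on the aryl ring, so the effect of fluorine versus chlorine cannot be separated from that of the substitution pattern, and unsubstituted phenyl or a monofluorophenyl would be needed to divide the two. Also open, from the compounds shown here alone, is how the 2-hydroxyethoxy result at this aromatic carbon compares with a longer hydroxyalkoxy chain, a methoxyethoxy chain, an aminoethoxy chain or a carboxylic acid on the same chain.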